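Propyl to (furan-2-yl)methyl at the amide-type nitrogen

A few compounds are considered here, and "the series" means these few. Any claim that something is new, unique, unknown or untested is made for them only; others in the source may bear on it.

Compound 1 `Cc1nc(N)sc1CCCN/C(N)=N/C(=O)NCC(C)CCc1ccccc1` and compound 2 `CCCNC(=O)/N=C(\N)NCCCc1sc(N)nc1C` share one core and were both tested in an assay on membranes from Sf9 cells for displacement of a labelled ligand from histamine H2 receptor (Homo sapiens), read by scintillation counting, with a stated time of 60 min; a higher number here means a weaker inhibitor, a lower number a stronger inhibitor. Compound 1 gives 63.1 nM, while compound 2 gives 105 nM. Going by the values given here, the one measured step between them, a 1.7-fold higher number from compound 1 to compound 2 (0.22 log units; within the scatter), lies within the scatter, so compound 2 stands level with compound 1, its only neighbour among the two numbers available. Compound 3 `Cc1nc(N)sc1CCCN/C(N)=N/C(=O)NCc1ccco1` has not been measured; it differs from compound 2 by furan-2-yl in place of ethyl on a saturated chain carbon bound to an amide-type nitrogen. Among the compounds with values here, no measured step touches that place: the single step known, a 1.7-fold higher number from compound 1 to compound 2 (0.22 log units; within the scatter), concerns another part of the chain and was itself small. With nothing in the data pointing either way, compound 3 is expected to stay close to compound 2, the estimated step of a 1.2-fold lower number from compound 2 to compound 3 (0.09 log units; within the scatter) being no larger than the scatter. For compound 3 in this assay the estimate is 85 nM, within 30 nM to 250 nM.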

Compound 3, inhibition constant: 10.5 nM
Compound 3: middle estimate off by 8.1-fold (0.91 log units), on the high side; the whole stated range lies above it.
By their numbers in this assay, from the lowest: compound 3; then compounds 1 and 2 (each within the scatter of the next).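

At the saturated chain carbon bound to an amide-type nitrogen, placing furan-2-yl for ethyl gives a 10-fold lower number from compound 2 to compound 3 (1.00 log units; beyond the scatter) in this assay, which shows that this place responds strongly to the change, whereas the earlier step of a 1.7-fold higher number from compound 1 to compound 2 (0.22 log units; within the scatter) at another part of the chain stayed within the scatter. The change brings in one five-membered aromatic ring with 1 hetero atom and 1 hydrogen-bond acceptor, with 5 heavy atoms in place of 2, and these features arrive together in a single step. Nothing available explains why the number falls.

The compounds shown cannot separate the contribution of the ring from that of its oxygen. On these data alone, whether a longer chain such as butyl, or an amine, at this place would also lower the number remains open.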